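Swapping chloro for fluoro in a cytotoxicity series

The compounds below may be only part of what the source reports. "The series", "measured", "known", "first", "only" and "open" are said of these compounds alone.

Of the compounds shown here, three have been tested, and a fourth awaits testing. Compound 1 `CONC(=S)N/N=C1\C(=O)N(CN2CCN(c3ccccc3)CC2)c2ccc(F)cc21` and compound 2 `CONC(=S)N/N=C1\C(=O)N(CN2CCN(c3ccccc3)CC2)c2ccc(Cl)cc21` share a core and differ only at one aromatic carbon. In an ADME assay on MT4 cells (Homo sapiens) for cytotoxicity, read by spectrophotometry, with a stated time of 5 days (a lower number here means that less compound is tolerated, a higher number that more compound is tolerated), compound 1 gives 227000 nM, and compound 2 gives 267000 nM. The move is a 1.2-fold lower number from compound 2 to compound 1 (0.07 log units; within the scatter); the change behind it is fluoro in place of chloro on an aromatic carbon.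

Compound 3 `CCn1cc(C(=O)O)c(=O)c2cc(F)c(N3CCN(CN4C(=O)/C(=N\NC(=S)NOC)c5cc(Cl)ccc54)C(C)C3)c(F)c21` carries a larger core; the difference between the two cores is not broken down here. In this assay compound 3 gives 180000 nM, and its gaps to compound 1 and to compound 2 are both within the scatter, so no ordering among the three can be read from these numbers.

Compound 4 `CCn1cc(C(=O)O)c(=O)c2cc(F)c(N3CCN(CN4C(=O)/C(=N\NC(=S)NOC)c5cc(F)ccc54)C(C)C3)c(F)c21` is related to compound 3 by fluoro in place of chloro on an aromatic carbon. The place is described in the same words for both pairs, so this is the same change, made once on each core.

Because the earlier move was a 1.2-fold lower number from compound 2 to compound 1 (0.07 log units; within the scatter) and lay within the scatter, the step on the larger core is expected to be small as well, about a 1.1-fold lower number from compound 3 to compound 4 (0.04 log units; within the scatter). Compound 4 is therefore estimated at 165000 nM, with a range from 95000 nM to 290000 nM.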

Compound 4, half-maximal cytotoxic concentration: 178000 nM
For compound 4 the middle estimate is 1.1-fold (0.03 log units) below the measured one, and the stated range covers the measured number.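

Measured in this assay, putting fluoro in place of chloro on the larger core gives a 1.0-fold lower number from compound 3 to compound 4 (0.00 log units; within the scatter), so the swap leaves no readable mark on this core. Set beside the same swap on the smaller core, the two steps agree: the same change on two cores in this assay, a 1.2-fold lower number (0.07 log units; within the scatter) from compound 2 to compound 1 and a 1.0-fold lower number (0.00 log units; within the scatter) from compound 3 to compound 4, 1.2-fold (0.07 log units) apart, within the scatter of two such steps. For the compounds shown here, this shows that, on these two cores, the swap produced no step that can be told apart from the ordinary differences between repeated measurements, but this is agreement between two steps that are each within the scatter, not a sizeable effect seen to carry over from one core to the other, and two cores cannot establish a rule for a third.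

On these data alone, only chloro and fluoro appear at this aromatic carbon, so it remains open whether a different group there, such as bromo, a nitrile or an amine, would give a step large enough to read in this assay, and whether such a step would then match on both cores. The compounds shown also leave open whether the match between the cores would hold in any measurement other than this one.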